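The source may report more compounds than this note shows. Statements on the series, on what has been measured and on what is new or still open speak of the compounds shown alone.

Measured compounds in a functional assay on P388 cells (Mus musculus) for cytotoxicity, read by MTT assay, with a stated time of 72 h; a higher number here means a weaker inhibitor, a lower number a stronger inhibitor:
compound 1, `OCC#CCSc1cnc2ccccc2c1[Se]CC#CCBr`, gives 1.6 ug/mL;
compound 2, `OCC#CCSc1cnc2ccccc2c1[Se]CC#CCO`, gives 4.1 ug/mL;
compound 3, `C#CC[Se]c1c(SCC#CCO)cnc2ccccc12`, gives 2.5 ug/mL.

Compound 1 has the lowest of the three numbers, but only its step to compound 2 lies beyond the scatter. That step, a 2.6-fold higher number from compound 1 to compound 2 (0.41 log units; beyond the scatter), is a modest one, and it goes with bromo in place of hydroxy on a saturated chain carbon bound to a triple-bonded carbon. The step of a 1.6-fold higher number from compound 1 to compound 3 (0.19 log units; within the scatter) and the step of a 1.6-fold lower number from compound 2 to compound 3 (0.21 log units; within the scatter) both stay within the scatter, so compounds 1 and 3, and compounds 2 and 3, cannot be set in order against one another.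

Compound 4, `C#CCSc1cnc2ccccc2c1[Se]CC#CCBr`, has not yet been measured in this assay. It differs from compound 1 by hydrogen in place of hydroxymethyl on a triple-bonded carbon. The same change, made on the same place, is already seen between compound 2 and compound 3, where it is described as hydrogen in place of hydroxymethyl on a triple-bonded carbon and made the step of a 1.6-fold lower number from compound 2 to compound 3 (0.21 log units; within the scatter). The two pairs rest on cores that differ by bromo in place of hydroxy on a saturated chain carbon bound to a triple-bonded carbon.

Because the step of a 1.6-fold lower number from compound 2 to compound 3 (0.21 log units; within the scatter) stayed within the scatter, the same change on the core of compound 1 is expected to move the number little. The step from compound 1 to compound 4 is therefore estimated at a 1.2-fold lower number from compound 1 to compound 4 (0.09 log units; within the scatter). Compound 4 is expected to give about 1.3 ug/mL, with a range of 0.6 ug/mL to 2.8 ug/mL.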

Compound 4, concentration for 50% inhibition: 1.2 ug/mL
Compound 4: the middle estimate sits 1.1-fold (0.03 log units) above what was measured, and the stated range covers the measured number.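

In this assay, the exchange of hydroxymethyl for hydrogen on a triple-bonded carbon gives a 1.3-fold lower number from compound 1 to compound 4 (0.12 log units; within the scatter), and the same change on the two cores reads alike: the same change on two cores in this assay, a 1.6-fold lower number (0.21 log units; within the scatter) from compound 2 to compound 3 and a 1.3-fold lower number (0.12 log units; within the scatter) from compound 1 to compound 4, 1.2-fold (0.09 log units) apart, within the scatter of two such steps

The swap from 4-hydroxybut-2-yn-1-yl to propargyl therefore moved the number little on both the core of compound 1 and the core of compound 2, and so far the change carries from one core to the other without a visible difference. This does not show that the hydroxymethyl group is without any effect, or that compound 4 can be set in order against compound 1, and two pairs whose steps both stay within the scatter are only a weak test, one that says nothing about cores beyond these two.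

The compounds shown place only hydroxymethyl or hydrogen on this triple-bonded carbon, so it remains open whether an amine, a carboxylic acid or a longer chain there would leave the number as little moved. From the compounds shown here alone, it also remains open whether the change would read the same on a core carrying some other group, such as an amine, in place of the bromo or hydroxy.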